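This account rests on a few compounds, and the source may have more. Where it says the series, first, only, none or still open, it means among the compounds named here.

Compound 2 `CCOC(=O)c1cc(-c2cccc(OC(=O)NC3CCCCC3)c2)nn1C` gives 227 nM in an assay on isolated protein for inhibition of Fatty-acid amide hydrolase 1 (Homo sapiens), read by fluorescence, with a stated time of 30 min; a lower number here means a stronger inhibitor, a higher number a weaker inhibitor; its nearest neighbour is compound 1 `CCOC(=O)c1cc(-c2ccc(OC(=O)NC3CCCCC3)cc2)n(-c2ccc(Cl)cc2)n1`, which in this assay gives 281 nM, a gap within the scatter, so no order between the two is claimed. Compound 3 `CCOC(=O)c1cc(-c2cccc(OC(=O)NC3CCCCC3)c2)nn1-c1ccc(Cl)cc1` is not yet measured; it differs from compound 2 by 4-chlorophenyl in place of methyl on an aromatic nitrogen. Going by the values given here, no measured pair isolates this change, so for a 1.1-fold higher number from compound 2 to compound 3 (0.04 log units; within the scatter) no step beyond the scatter is expected in either direction. For compound 3 the estimate in this assay is 250 nM, with a range from 80 nM to 800 nM.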

Compound 3, half-maximal inhibitory concentration: 353 nM
Beside the measured number, compound 3's estimate is 1.4-fold (0.15 log units) below it; the range from low to high includes it.
By their numbers in this assay, from the lowest: compounds 2, 1 and 3 (each within the scatter of the next).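

In this assay, going by these compounds alone, 4-chlorophenyl in place of methyl on the aromatic nitrogen gives a 1.6-fold higher number from compound 2 to compound 3 (0.19 log units; within the scatter), the first pair to isolate this change. The position thus carries either a single methyl or a six-membered aromatic ring with no step beyond the scatter. No evidence at hand bears on this result.

Going by these compounds, whether an unsubstituted phenyl, a benzyl group or a longer alkyl chain on this nitrogen would read the same remains open. So does the effect of an amine on the added ring, or of a carboxylic acid in place of the ethoxycarbonyl group.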